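Chloro for hydrogen on the aromatic ring of compound 1

A few compounds are considered here, and "the series" means these few. Any claim that something is new, unique, unknown or untested is made for them only; others in the source may bear on it.

Going by the values given here, compound 1 `C/N=C(\S)n1nc(-c2ccccc2)nc1N` is read in a functional assay on the whole organism for inhibition, with Rattus norvegicus as the target, at a dose of 30 mg/kg (a lower number here means less inhibition, a higher number more inhibition at the dose given (going by the name of the read-out)), where compound 1 gives 54%, the highest of the two numbers known. Compound 2 `C/N=C(\S)n1nc(-c2ccc(N)cc2)nc1N` has no result reported in this assay. Compound 3 `C/N=C(\S)Nc1ccc(-c2nc(N)n(/C(S)=N/C)n2)cc1`, which carries a group of 5 heavy atoms in place of a hydrogen atom on an aromatic carbon, gives 31% in this assay, a step of a number 23 percentage points lower from compound 1 to compound 3 (beyond the scatter). Compound 4 `C/N=C(\S)n1nc(-c2ccccc2Cl)nc1N` differs from compound 1 by chloro in place of hydrogen on an aromatic carbon. Among the compounds with values here, no measured step bears directly on this change; the only known step puts a much larger group at another aromatic carbon. A single chloro is expected to shift the number in this assay by no more than the scatter, a number 6 percentage points lower from compound 1 to compound 4 (within the scatter). Compound 4 is estimated at 48%, within 25% to 70%.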

Compound 4, a percentage reported as inhibition, in the whole organism at one dose (the size of the read-out at that dose, not a potency): 18%
Estimate against measurement, compound 4: 30 percentage points above; measured number below the stated range.
By their numbers in this assay, from the lowest: compound 4; then compound 3; then compound 1.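

In this assay, going by these compounds alone, replacing hydrogen with chloro at this aromatic carbon, ortho to a large group, gives a number 36 percentage points lower from compound 1 to compound 4 (beyond the scatter), the only measured change at this place. A single added heavy atom is therefore enough to lower the inhibition at the dose given by a large step. No measurement available here accounts for this drop. Still open, from the compounds shown here alone, is whether the drop is specific to chloro or would also appear with a fluoro or methoxy group at the same place. Going by these compounds, the effect of an amine at this place also remains open.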